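The source may hold more compounds than are shown below. What is called first, only, known or untested is meant among the compounds shown, and "the series" means these compounds.

Measured compounds:
- compound 1, `CCCCCCCCCCCCCC[C@H](OCOC)[C@H](CO)NC(=O)OC(C)(C)C`: 18.4%
- compound 2, `CCCCCCCCCCCCCC[C@H](OCOC)[C@H](CN(C(C)C)C(C)C)NC(=O)OC(C)(C)C`: 26.6%

Both were tested in a functional assay on NCI-H358 cells (Homo sapiens) for antiproliferative activity, read by sulforhodamine B assay, with a stated time of 48 h, tested at 10 uM; on this read-out lower numbers stand for less inhibition and higher numbers for more inhibition at the one concentration tested (going by the name of the read-out). Compound 2 has the larger of the two numbers shown, with compound 1 as its only neighbour, but the step of a number 8.2 percentage points higher from compound 1 to compound 2 (within the scatter) lies within the scatter, so the two values are not separated. Among the compounds with values here, that single step, hydroxy to diisopropylamino, is the only measured comparison so far.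

Compound 3, `CCCCCCCCCCCCCC[C@H](OCOC)[C@H](CN(CCCC)CCCC)NC(=O)OC(C)(C)C`, is not yet measured. It differs from compound 2 as follows: dibutylamino in place of diisopropylamino on a saturated chain carbon, two bonds along the chain from an amide-type nitrogen. Within the data shown here, no measured step exchanges one dialkylamino group for another, so nothing bears on this change directly; the one step seen, a number 8.2 percentage points higher from compound 1 to compound 2 (within the scatter), stayed within the scatter although it replaced hydroxy with diisopropylamino. On that basis the step to compound 3 in this assay is expected to be no larger than the scatter, with no clear direction. Compound 3 is estimated at 30% in this assay, with a range from 12% to 48%, which corresponds to an expected step of a number 3.4 percentage points higher from compound 2 to compound 3 (within the scatter).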

Compound 3, a percentage reported as inhibition, at one concentration (the size of the read-out at that concentration, not a potency): 25.1%
The estimate for compound 3 lay 4.9 percentage points above the measured number; measured number inside the range.
By their numbers in this assay, from the lowest: compounds 1, 3 and 2 (each within the scatter of the next).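

Within the data shown here, exchanging diisopropylamino for dibutylamino on a saturated chain carbon, two bonds along the chain from an amide-type nitrogen, gives a number 1.5 percentage points lower from compound 2 to compound 3 (within the scatter) in this assay, the first direct comparison of two dialkylamino groups at this place, and these two groups are not separated despite the different shapes and sizes of their alkyl groups. Dibutylamino in place of hydroxy gives a number 6.7 percentage points higher from compound 1 to compound 3 (within the scatter) in this assay, so a second amine joins diisopropylamino in staying unseparated from the hydroxy compound, and all three compounds now lie within the scatter of one another, with no order among them. No accompanying measurement speaks to the reason for these numbers.

Going by these compounds, it remains open whether a different group at this place, such as a primary amine, a piperidine ring or a carboxylic acid, or longer chains on the amine nitrogen, would give a step beyond the scatter in this assay. Also open, on these data alone, is whether the shared core carries the inhibition seen here, since changes elsewhere in the core, such as replacing the tert-butyl carbamate with a free amine, fall outside these compounds.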